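Benzyl for phenyl on two different five-membered cores

The source may hold more compounds than are shown below. What is called first, only, known or untested is meant among the compounds shown, and "the series" means these compounds.

In a functional assay on the whole organism (plasma, strain Wistar) with Rattus norvegicus as the target, with a stated time of 15 days, at a dose of 100 mg/kg by the oral route (a lower number here means a weaker effect, a higher number a stronger effect of the compound at the dose given), three compounds have been measured so far:
Compound 1, `O=C1NC(=O)/C(=C/c2ccc(OCCSc3nnc(-c4ccccc4)[nH]3)cc2)S1`, gives 22.9%.
Compound 2, `O=C1NC(=O)/C(=C/c2ccc(OCCSc3nnc(Cc4ccccc4)[nH]3)cc2)S1`, gives 34.4%.
Compound 3, `O=C1NC(=O)/C(=C/c2ccc(OCCSc3nnc(-c4ccccc4)o3)cc2)S1`, gives 20.1%.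

Compound 1 and compound 2 share a core and differ by benzyl in place of phenyl on an aromatic carbon. That change made a step of a number 11.5 percentage points higher from compound 1 to compound 2 (beyond the scatter) in this assay. Compound 3 carries a different core; how it differs from that of compound 1 is not broken down here, and its value sits close to that of compound 1.

Compound 4, `O=C1NC(=O)/C(=C/c2ccc(OCCSc3nnc(Cc4ccccc4)o3)cc2)S1`, has not yet been measured in this assay. It differs from compound 3 by benzyl in place of phenyl on an aromatic carbon. Going by the values given here, this is the same kind of change as the one from compound 1 to compound 2, but not the same: here the carbon belongs to a five-membered aromatic ring with 2 nitrogen and 1 oxygen, next to the ring nitrogen and next to the ring oxygen, whereas in compound 1 it sits between two ring nitrogen atoms of a ring with 3 nitrogen. The expected step of a number 9.9 percentage points higher from compound 3 to compound 4 (within the scatter) rests on a number 11.5 percentage points higher from compound 1 to compound 2 (beyond the scatter), with wider uncertainty since the surroundings differ. Compound 4 is therefore estimated to give 30% in this assay.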

Compound 4, a percentage reported as activity, at one dose (the size of the read-out at that dose, not a potency): 23.1%
The estimate for compound 4 lay 6.9 percentage points above the measured number, within the range that was stated.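

Benzyl in place of phenyl on the core of compound 3 gave a number 3 percentage points higher from compound 3 to compound 4 (within the scatter) in this assay, a step that, unlike the earlier one, does not stand clear of the scatter. Set side by side, the two steps cannot be told apart: the same change on two cores in this assay, a number 11.5 percentage points higher (beyond the scatter) from compound 1 to compound 2 and a number 3 percentage points higher (within the scatter) from compound 3 to compound 4, 8.5 percentage points apart, within the scatter of two such steps This does not show that the change carries over in full from one core to the other, nor that its size depends on the core, since one pair on each core cannot separate a real difference from scatter.

The compounds shown leave open whether phenethyl, a longer chain, would change the number on either core. They also leave open what an amine or a carboxylic acid on the benzyl group would do.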